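The source may hold more compounds than are shown below. What is called first, only, known or untested is meant among the compounds shown, and "the series" means these compounds.

Compound 1, `Cc1cc(OCCCS(C)(=O)=O)cc(C)c1-c1cccc(COc2ccc(OC(C)C(=O)O)cc2)c1`, gives 389 nM in a functional assay on CHO cells for agonist activity at Free fatty acid receptor 1 (Homo sapiens), read by fluorescence and calcium flux; on this read-out higher numbers stand for an effect only at larger amounts of compound and lower numbers for an effect already at smaller amounts. Compound 2, `Cc1cc(OCCCS(C)(=O)=O)cc(C)c1-c1cccc(COc2ccc(OC(C)(C)C(=O)O)cc2)c1`, is recorded as "not determined" (no result reported) in this assay, so no number is available for it. Compound 3, `Cc1cc(OCCCS(C)(=O)=O)cc(C)c1-c1cccc(COc2ccc(OCC(=O)O)c(Cl)c2)c1`, gives 92.6 nM in this assay.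

Among the two numbers available, compound 1 stands highest, and its only measured neighbour is compound 3, reached by the step of a 4.2-fold lower number from compound 1 to compound 3 (0.62 log units; beyond the scatter). Compound 4, `Cc1cc(OCCCS(C)(=O)=O)cc(C)c1-c1cccc(COc2ccc(OCC(=O)O)c(F)c2)c1`, differs from compound 1 in the change (4-(carboxymethoxy)-3-fluorophenyl in place of 4-(1-carboxyethoxy)phenyl on an oxygen on a saturated carbon). Among the compounds with values here, the one step that bears on this is the one from compound 1 to compound 3, which exchanged the same group for its chlorine-bearing counterpart and gave a modest drop in the number. A similar direction is expected here, with a step of about a 3.0-fold lower number from compound 1 to compound 4 (0.48 log units; beyond the scatter). For compound 4 the estimated value in this assay is 130 nM, within a range of 50 nM to 350 nM.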

Compound 4, half-maximal effective concentration: 62.3 nM
Compound 4: the middle estimate sits 2.1-fold (0.32 log units) above what was measured, within the range that was stated.
By their numbers in this assay, from the lowest: compounds 4 and 3 (each within the scatter of the next); then compound 1.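

Fluoro in place of chloro on an aromatic carbon gives a 1.5-fold lower number from compound 3 to compound 4 (0.17 log units; within the scatter) in this assay and so leaves the two halogens level on this read-out. Measured against 4-(1-carboxyethoxy)phenyl, the fluorine-bearing group gives a 6.2-fold lower number from compound 1 to compound 4 (0.80 log units; beyond the scatter) and so joins the chlorine-bearing group in lowering the number. Nothing measured here gives a reason for either step.

The shorter acid chain and the halogen enter together, so these compounds cannot say which of the two carries the change from compound 1. From the compounds shown here alone, how bromo or nitrile in place of fluoro would read also stays open.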